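This account rests on a few compounds, and the source may have more. Where it says the series, first, only, none or still open, it means among the compounds named here.

Measured compounds:
compound 1 `COc1ccc(-c2cc(C(C)=O)c3[nH]c(-c4ccc(F)cc4)cc3c2)cc1` — 88.4%
compound 2 `CC(=O)c1cc(/C=C/c2ccc(F)cc2)cc2cc(-c3ccccc3)[nH]c12` — 89.7%
compound 3 `CC(=O)c1cc(/C=C/c2ccccc2)cc2cc(-c3ccc(F)cc3)[nH]c12` — 98.4%

All three were tested in a functional assay on MCF7 cells (Homo sapiens) for cytotoxicity, read by MTT assay, with a stated time of 2 days, tested at 0.1 uM; a higher number here means a weaker effect of the compound at the concentration tested, a lower number a stronger effect. Within the data shown here, the three numbers lie close together: compound 3 differs from compound 2 and from compound 1 by amounts that fall within the scatter, and the one single-point change measured so far, a number 10 percentage points higher from compound 1 to compound 3 (within the scatter), also stays within it. Compound 4 `CC(=O)c1cc(/C=C/c2ccc(F)cc2)cc2cc(-c3ccc(F)cc3)[nH]c12` is the next compound. Its difference from compound 3 is fluoro in place of hydrogen on an aromatic carbon. Among the measured compounds shown here, no measured step shows this exact change on its own. Compound 2 already carries the 2-(4-fluorophenyl)ethenyl group and, in this assay, compound 2 gives a number close to that of compound 3, so nothing in the data points to a step beyond the scatter. The expected step is a number 5.4 percentage points lower from compound 3 to compound 4 (within the scatter), that is, essentially none. Compound 4 is therefore estimated to give 93% in this assay, with a likely range from 80% to 100%.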

Compound 4, a percentage reported as activity, at one concentration (the size of the read-out at that concentration, not a potency): 98.8%
The estimate for compound 4 lay 5.8 percentage points below the measured number; low and high end bracket the measured number.
By their numbers in this assay, from the lowest: compounds 1, 2, 3 and 4 (each within the scatter of the next, the first and the last beyond it).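

In this assay, fluoro in place of hydrogen on the ring of the 2-phenylethenyl group gives a number 0.4 percentage points higher from compound 3 to compound 4 (within the scatter), and fluoro in place of hydrogen on the phenyl group gives a number 9.1 percentage points higher from compound 2 to compound 4 (within the scatter), so at both places this small swap stays within the scatter. Among these compounds, the one step beyond the scatter, and only a modest one, is a number 10.4 percentage points higher from compound 1 to compound 4 (beyond the scatter), where 2-(4-fluorophenyl)ethenyl stands in place of 4-methoxyphenyl. Nothing reported with these numbers offers an explanation for them.

The compounds shown carry only hydrogen or fluoro at these two ring places, so the effect of an amine, a carboxylic acid or a nitrile there remains open. Also open, from the compounds shown here alone, is how these compounds behave at other concentrations, since every number here comes from a single one.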